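The source may report more compounds than this note shows. Statements on the series, on what has been measured and on what is new or still open speak of the compounds shown alone.

Measured so far in an assay on CHO cells for displacement of a labelled ligand from adenosine receptor A3 (Homo sapiens); on this read-out lower numbers stand for stronger inhibition and higher numbers for weaker inhibition:
Compound 1 `CCCn1cnc2ncnc(N)c21` gives > 100000 nM.
Compound 2 `CCC(C)n1cnc2ncnc(N)c21` gives > 100000 nM.
Compound 3 `CC(C)Cn1cnc2c(N)ncnc21` gives > 100000 nM.

Each of these values is a limit of this assay and not a number. Compound 2 stands at that limit, and the same holds for compound 1 and compound 3, so the series has not yet given a readable number at all, (the limit of > 100000 nM in this assay, at which 3 of the 3 values shown sit). Within the data shown here, the single step between measured compounds that differ in one place, a step that the two limits leave unreadable from compound 1 to compound 2, cannot be sized for this reason; it only shows that adding a methyl on the chain did not bring the value inside the measurable range.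

Compound 4 `Nc1ncnc2ncn(CCO)c12` is not yet measured. It differs from compound 2 by 2-hydroxyethyl in place of sec-butyl on an aromatic nitrogen. Among the measured compounds shown here, no measured step bears directly on this change: the only measured step is unreadable, and every compound measured so far sits at the limit. The expectation for compound 4 in this assay is therefore that it too returns a limit rather than a number, with no step beyond the scatter readable. Compound 4 is estimated at 150000 nM, in the range 30000 nM to 1000000 nM. The step from compound 2 to compound 4 is accordingly expected as a step that the limit leaves unreadable from compound 2 to compound 4, most likely reported again only as a limit.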

Compound 4, inhibition constant: > 100000 nM
Compound 4: no number, only a limit; the forecaster's own chance of this, stated with the estimate: 85%; the middle value lies beyond the limit too.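

In this assay compound 4 gives only a limit and not a number, as do compound 1 and compound 2, so the new steps to compound 4 from compound 1 and compound 2 cannot be read: the limit of > 100000 nM in this assay, at which 4 of the 4 values shown sit.

The compounds shown leave open whether any group on the aromatic nitrogen of the shared core brings a value inside the measurable range.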